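Widening the sulfonyl aryl: a second chlorine enters

The source may hold more compounds than are shown below. What is called first, only, known or untested is meant among the compounds shown, and "the series" means these compounds.

Three analogues share a core that carries an amide or sulfonamide on one aromatic ring. Compound 1 `O=C(Nc1cccc(/C=C/C(=O)c2nc3ccccc3[nH]2)c1)c1cccc(Cl)c1` gives 1120 nM in a functional assay on HCT-116 cells (Homo sapiens) for antiproliferative activity, read by MTT assay, with a stated time of 48 h; a higher number here means a weaker inhibitor, a lower number a stronger inhibitor; compound 2 `Cc1cccc(C(=O)Nc2cccc(/C=C/C(=O)c3nc4ccccc4[nH]3)c2)c1` gives 1420 nM; compound 3 `O=C(/C=C/c1cccc(NS(=O)(=O)c2ccccc2Cl)c1)c1nc2ccccc2[nH]1` gives 987 nM. Compound 3 sits alongside the other two, since a 1.1-fold lower number from compound 1 to compound 3 (0.05 log units; within the scatter) and a 1.4-fold lower number from compound 2 to compound 3 (0.16 log units; within the scatter) both stay within the scatter, as does a 1.3-fold higher number from compound 1 to compound 2 (0.10 log units; within the scatter). Compound 4 `O=C(/C=C/c1cccc(NS(=O)(=O)c2cc(Cl)cc(Cl)c2)c1)c1nc2ccccc2[nH]1` differs from compound 3 by 3,5-dichlorophenyl in place of 2-chlorophenyl on a sulfonyl sulfur. Within the data shown here, no measured step changes the aryl on the sulfonyl sulfur itself, and every step seen so far stayed within the scatter, so only a small step is expected in this assay, with no clear direction. Compound 4 is therefore estimated at 900 nM, between 350 nM and 2500 nM, meaning an expected step of a 1.1-fold lower number from compound 3 to compound 4 (0.04 log units; within the scatter).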

Compound 4, half-maximal inhibitory concentration: 2840 nM
For compound 4 the middle estimate is 3.2-fold (0.50 log units) below the measured one; measured number above the stated range.
By their numbers in this assay, from the lowest: compounds 3, 1, 2 and 4 (each within the scatter of the next, the first and the last beyond it).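

Among these compounds, the aryl on the sulfonyl sulfur is the first place in this set where a change moves the number beyond the scatter in this assay, with a 2.9-fold higher number from compound 3 to compound 4 (0.46 log units; beyond the scatter) on replacing 2-chlorophenyl with 3,5-dichlorophenyl. The earlier steps shown here, including the one from amide to sulfonamide, all stayed within the scatter. This swap alters both the number of chlorines and where they sit, so the two effects cannot be separated.

From the compounds shown here alone, how methoxy, an amine or a longer alkyl chain on the sulfonyl sulfur would behave remains open. No measurement shown here accounts for the step.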